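This account rests on a few compounds, and the source may have more. Where it says the series, first, only, none or still open, it means among the compounds named here.

Working notes on the series, all read in a functional assay on NCI-H460 cells (Homo sapiens) for inhibition, read by MTT assay, with a stated time of 4 days; on this read-out higher numbers stand for weaker inhibition and lower numbers for stronger inhibition. Compound 1 `COc1cc(NC(C)CCCNC(=O)NN)c2ncccc2c1` returns only a limit in this assay, > 100000 nM. Compound 2 `CCOC(=O)N(C)C(c1ccccc1)c1ccccc1` also stops at a limit in this assay, >= 100000 nM. Compound 3 `NNC(=O)NC(c1ccccc1)c1ccc(Cl)cc1` gives a limit in this assay as well, > 100000 nM. Within the data shown here, because every value is a limit, no step between measured compounds can be read; the three values show only that none of them reaches a measurable number, with the limit of > 100000 nM in this assay, at which 2 of the 3 values shown sit, and the limit of >= 100000 nM in this assay, at which 1 of the 3 values shown sits, marking where they sit.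

Compound 4 `COc1cc(NC(C)CCCNC(=O)NNC(=O)NC(CO)(CO)CO)c2ncccc2c1` is not yet measured in this assay. Compared with compound 1 the change is (2-hydroxy-1,1-bis(hydroxymethyl)ethyl)carbamoyl in place of hydrogen on an amine nitrogen, the new group entering on an amine nitrogen whose other neighbour is an amide-type nitrogen. Among the measured compounds shown here, with compound 1 at a limit and no measured step anywhere in the set, the numbers give no direction to expect; the step is expected to stay within the scatter, and a further limit is the likely outcome. The expected step is a number no higher from compound 1 to compound 4 (the limit leaves the size open). For compound 4 the estimate in this assay is 100000 nM, with a range from 30000 nM to 300000 nM.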

Compound 4, half-maximal inhibitory concentration: > 100000 nM
Compound 4 ended at the assay's limit (the forecaster's own chance of this, stated with the estimate: 85%); the middle value lies on the limit itself.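

Among these compounds, compound 1 and compound 4 both stop at a limit in this assay, so no step between them can be read. The compounds shown leave open whether any change to the shared core would give a measurable number rather than a further limit.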